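The source may hold more compounds than are shown below. What is called first, only, known or untested is meant among the compounds shown, and "the series" means these compounds.

Compound 1 `COCCOCCOc1cccc2ccc(N)nc12` is the starting point. In an assay on cells with melanin-concentrating hormone receptor 1 (Homo sapiens) as the target, read by radioligand binding (on this read-out higher numbers stand for weaker inhibition and lower numbers for stronger inhibition), compound 1 gives > 2000 nM, which is a limit of the assay rather than a number. Compound 2 `CCOCCOc1cccc2ccc(N)nc12` gives in this assay a reading of > 2000 nM, again only a limit. Compound 3 `Nc1ccc2cccc(OCC3CCCO3)c2n1` likewise gives in this assay a reading of > 2000 nM, a limit as well. The step from compound 1 to compound 2 is a step that the two limits leave unreadable from compound 1 to compound 2, that from compound 1 to compound 3 is a step that the two limits leave unreadable from compound 1 to compound 3, and that from compound 2 to compound 3 is a step that the two limits leave unreadable from compound 2 to compound 3; none of them can be sized because of the limit of > 2000 nM in this assay, at which 3 of the 3 values shown sit.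

Compound 4 `Nc1ccc2cccc(OCC3CCC3)c2n1` differs from compound 1 by cyclobutyl in place of (2-methoxyethoxy)methyl on a saturated chain carbon bound to an oxygen on an aromatic ring. Among the compounds with values here, no measured step reads on this change, and the three neighbours give no number to anchor it. The expectation is therefore that compound 4 also sits at or near the limit, with a step estimated as a step that the limit leaves unreadable from compound 1 to compound 4. Compound 4 is expected to show about 3000 nM, within a range from 800 nM to 12000 nM.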

Compound 4, half-maximal inhibitory concentration: 432 nM
The estimate for compound 4 lay 6.9-fold (0.84 log units) above the measured number, and the stated range ends above it.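

Among the compounds shown, cyclobutyl on the saturated chain carbon bound to an oxygen on an aromatic ring gives the only reading in this assay that is a number rather than a limit, with an at least 4.6-fold lower number from compound 1 to compound 4 (0.66 log units; beyond the scatter), an at least 4.6-fold lower number from compound 2 to compound 4 (0.66 log units; beyond the scatter) and an at least 4.6-fold lower number from compound 3 to compound 4 (0.66 log units; beyond the scatter). Cyclobutyl is a ring of carbon only, whereas (2-methoxyethoxy)methyl, ethoxymethyl and oxolan-2-yl all contain oxygen, so across these four compounds the measurable number goes with the group lacking oxygen, and none of them goes against this. Each of these steps gives only a minimum, and the steps among compound 1, compound 2 and compound 3 cannot be read, because those compounds sit at a limit: the limit of > 2000 nM in this assay, at which 3 of the 4 values shown sit.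

From the compounds shown here alone, it remains open whether cyclopropyl, cyclopentyl or an open butyl chain at this place would read like compound 4. Going by these compounds, it is equally open whether a ring of carbon is needed at all, or whether a nitrogen-bearing ring such as pyrrolidinyl would be tolerated.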